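Ethyl esters, free acid and a cyano-benzyl analogue

The source may hold more compounds than are shown below. What is called first, only, known or untested is meant among the compounds shown, and "the series" means these compounds.

Measured compounds:
compound 1 `CCOC(=O)C(=O)CC(=O)/C=C/c1cc(C(=O)c2ccccc2)cn1Cc1ccccc1`: "not determined" (no result reported)
compound 2 `CCOC(=O)C(=O)CC(=O)/C=C/c1cc(C(=O)c2ccccc2)cn1Cc1ccc(C#N)cc1`: "not determined" (no result reported)
compound 3 `O=C(/C=C/c1cc(C(=O)c2ccccc2)cn1Cc1ccccc1)CC(=O)C(=O)O`: > 40000 nM

Compound 1 and compound 2 carry the ethyl ester of the shared chain; neither has a result in a functional assay on MOLT-4 cells (Homo sapiens) for inhibition, read by MTT assay, with a stated time of 48 h; on this read-out higher numbers stand for weaker inhibition and lower numbers for stronger inhibition. Among the measured compounds shown here, compound 3 is the free acid and the only one with a reading. Its figure, > 40000 nM, is a limit of this assay and not a number. For the measured compounds named here, compound 3 therefore stands at the weak end of what this assay can report, as the limit of > 40000 nM in this assay, at which 1 of the 3 values shown sits, shows, and no step between measured compounds is available to set a scale for the series.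

Compound 4 `N#Cc1ccc(Cn2cc(C(=O)c3ccccc3)cc2/C=C/C(=O)CC(=O)C(=O)O)cc1` is not yet measured. It differs from compound 3 by cyano in place of hydrogen on an aromatic carbon, benzyl becoming 4-cyanobenzyl. Going by the values given here, with no measured step to lean on, the change from compound 3 to compound 4 is expected to stay within the scatter, that is a number no higher from compound 3 to compound 4 (the limit leaves the size open). Compound 4 is thus expected at 40000 nM, with a range from 15000 nM to 120000 nM, and most likely this assay will again return only a limit.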

Compound 4, half-maximal inhibitory concentration: 40000 nM
Estimate against measurement, compound 4: no gap at the digits printed; measured number inside the range.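

Among the compounds shown here, compound 4 gives the first plain number, 40000 nM in this assay, with 4-cyanobenzyl in place of the benzyl of the free acid. Compound 3 gives > 40000 nM, which is a limit and not a number. Cyano in place of hydrogen, para to a large group, gives a number no higher from compound 3 to compound 4 (the limit leaves the size open), so this position carries the nitrile with the reading still at the weak end of what the assay reports, and the size of the step cannot be read, as it rests on a limit: the limit of > 40000 nM in this assay, at which 1 of the 4 values shown sits.

Open, on these data alone, is whether an amine or a methoxy group at this same position would bring a reading clearly stronger than that of compound 4. Also open, as far as these compounds go, is how the ethyl ester form compares with the free acid, as compound 1 and compound 2 have no result to set against it.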